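Methoxy in Place of Hydroxyethyl on the Sulfur Chain

The source may hold more compounds than are shown below. What is called first, only, known or untested is meant among the compounds shown, and "the series" means these compounds.

Compound 1 `CC(C)c1n[nH]c2c(NCc3ccc(-c4ccccn4)cc3)nc(SCCO)nc12`: 48 nM
Compound 2 `CC(O)CSc1nc(NCc2ccc(-c3ccccn3)cc2)c2[nH]nc(C(C)C)c2n1`: 62 nM
Compound 3 `CC(C)c1n[nH]c2c(NCc3ccc(-c4ccccn4)cc3)nc(SCC(C)(C)N)nc12`: 85 nM
Compound 4 `COCSc1nc(NCc2ccc(-c3ccccn3)cc2)c2[nH]nc(C(C)C)c2n1`: not yet measured

In a functional assay on HT cells (Homo sapiens) for antiproliferative activity, read by fluorescence, with a stated time of 72 h (on this read-out lower numbers stand for stronger inhibition of growth and higher numbers for weaker inhibition of growth), compound 2 gives 62 nM, the second highest of the three numbers. Its closest companion is compound 1, with a 1.3-fold higher number from compound 1 to compound 2 (0.11 log units; within the scatter), and the gap to compound 3 is a 1.4-fold higher number from compound 2 to compound 3 (0.14 log units; within the scatter). Compound 4 changes the sulfur chain of compound 2: methoxy in place of 1-hydroxyethyl on a saturated chain carbon bound to a sulfur. Going by the values given here, the steps that bear on this place are a 1.3-fold higher number from compound 1 to compound 2 (0.11 log units; within the scatter), a 1.8-fold higher number from compound 1 to compound 3 (0.25 log units; within the scatter) and a 1.4-fold higher number from compound 2 to compound 3 (0.14 log units; within the scatter); all three lie within the scatter, so no step beyond the scatter is expected here either. Compound 4 is therefore estimated at 70 nM, between 35 nM and 140 nM. The expected step is a 1.1-fold higher number from compound 2 to compound 4 (0.05 log units; within the scatter).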

Compound 4, concentration for 50% growth inhibition: 340 nM
Compound 4: middle estimate off by 4.9-fold (0.69 log units), on the low side; measured number outside the range, above it.
By their numbers in this assay, from the lowest: compounds 1, 2 and 3 (each within the scatter of the next); then compound 4.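

The sulfur chain tolerates less than the first three compounds suggested: in this assay, methoxy in place of 1-hydroxyethyl gives a 5.5-fold higher number from compound 2 to compound 4 (0.74 log units; beyond the scatter), and the other two chains show the same drop, with a 4.0-fold higher number from compound 3 to compound 4 (0.60 log units; beyond the scatter) and a 7.1-fold higher number from compound 1 to compound 4 (0.85 log units; beyond the scatter). Going by these compounds alone, compound 4 is the only compound here whose chain carries neither a hydroxyl nor an amino group. Nothing available explains this drop. The compounds shown leave open whether it tracks the missing hydrogen-bond donor or the smaller group, which a 2-methoxyethyl chain on the sulfur could separate.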